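Adding a Methoxy Group Beside the Carboxyphenyl Ether

The source may hold more compounds than are shown below. What is called first, only, known or untested is meant among the compounds shown, and "the series" means these compounds.

Of the compounds shown here, three built on one shared core have been measured in an assay on HEK293 cells for positive allosteric modulation of metabotropic glutamate receptor 3 (Rattus norvegicus), read by thallium flux, with a stated time of 2.5 min; a lower number here means that less compound is needed, a higher number that more compound is needed for the effect. Compound 1 `Cc1c(OCCCCOc2ccc(C(=O)O)cc2)ccc(C(=O)CC2CCCC2)c1O` reaches only a limit of this assay: compound 1 gives > 10000 nM, a boundary rather than a number (the limit of > 10000 nM in this assay, at which 1 of the 3 values shown sits). Compound 3 `Cc1c(OCCCCOc2cccc(C(=O)O)c2)ccc(C(=O)CC2CCCC2)c1O` differs only in where its carboxy group sits, and in this assay compound 3 gives 3400 nM; the step of an at least 2.9-fold lower number from compound 1 to compound 3 (0.46 log units; beyond the scatter) is a clear improvement. Compound 2 `COc1ccc(C(=O)O)cc1OCCCCOc1ccc(C(=O)C(C)C)c(O)c1C` gives 588 nM in this assay, so compound 3 holds the higher of the two measured numbers, with compound 2 lying below it by more than the scatter.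

Compound 4 `COc1ccc(C(=O)O)cc1OCCCCOc1ccc(C(=O)CC2CCCC2)c(O)c1C` differs from compound 3 in one place: methoxy in place of hydrogen on an aromatic carbon. Within the data shown here, no single measured step isolates this change. The step from compound 1 to compound 3 concerns the carboxy position, not a methoxy group. Compound 2 carries the same methoxy-bearing ring, but it also has a different ketone side chain, so its lower value cannot be credited to the methoxy alone. A modest gain is nevertheless expected, estimated as a 2.8-fold lower number from compound 3 to compound 4 (0.45 log units; beyond the scatter). For compound 4 the expected value is 1200 nM, with a range from 400 nM to 4000 nM.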

Compound 4, half-maximal effective concentration: 1020 nM
Beside the measured number, compound 4's estimate is 1.2-fold (0.07 log units) above it; measured number inside the range.
By their numbers in this assay, from the lowest: compounds 2 and 4 (each within the scatter of the next); then compound 3. At a limit, above all of these: compound 1.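

In this assay, the methoxy group now has a measured step of its own: placed on the aromatic carbon para to the carboxy group, with nothing else changed, it gives a 3.3-fold lower number from compound 3 to compound 4 (0.52 log units; beyond the scatter). With this methoxy-bearing ring in place, the ketone side chain makes no difference that can be read, since cyclopentylmethyl in place of isopropyl on the carbonyl carbon gives a 1.7-fold higher number from compound 2 to compound 4 (0.24 log units; within the scatter), so compound 2 and compound 4 cannot be put in order. Taken together, 5-carboxy-2-methoxyphenyl in place of 4-carboxyphenyl gives an at least 9.8-fold lower number from compound 1 to compound 4 (0.99 log units; beyond the scatter), and the size of that step is only a bound, with one of its ends a limit and not a number: the limit of > 10000 nM in this assay, at which 1 of the 4 values shown sits.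

The methoxy step rests on a single pair of compounds with the cyclopentylmethyl ketone, and whether it holds with the isopropyl ketone stays open, as compound 2 has no partner lacking the methoxy group among the compounds shown. Also open, going by these compounds, is whether an ethoxy group or a fluorine atom at this same place would give a similar step.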